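Aryl ether variation at the ketone end of the series

The source may hold more compounds than are shown below. What is called first, only, known or untested is meant among the compounds shown, and "the series" means these compounds.

Measured so far:
compound 1, `CC(C)[C@H](NC(=O)COc1cccc2ccccc12)C(=O)N[C@@H](CC(=O)O)C(=O)COc1ccc(-c2ccccc2)cc1`, 38700 nM
compound 2, `CC(C)[C@H](NC(=O)COc1cccc2ccccc12)C(=O)N[C@@H](CC(=O)O)C(=O)COc1ccc(Oc2ccccc2)cc1`, 19000 nM

In a functional assay with Homo sapiens as the target (a lower number here means a stronger inhibitor, a higher number a weaker inhibitor), compound 1 gives the highest of the two numbers, with compound 2 nearest at a 2.0-fold lower number from compound 1 to compound 2 (0.31 log units; beyond the scatter). Compound 3, `CC(C)[C@H](NC(=O)COc1cccc2ccccc12)C(=O)N[C@@H](CC(=O)O)C(=O)COc1cccc(F)c1`, is not yet measured; it differs from compound 1 by 3-fluorophenyl in place of 4-phenylphenyl on an oxygen on a saturated carbon. Among the measured compounds shown here, the one measured step, a 2.0-fold lower number from compound 1 to compound 2 (0.31 log units; beyond the scatter), touches the same aryl group but keeps two rings, so it bears only loosely here. Removing a ring is a larger change, and the step expected is a 1.6-fold higher number from compound 1 to compound 3 (0.19 log units; within the scatter), toward a weaker inhibitor. Compound 3 is estimated at 60000 nM, within 20000 nM to 180000 nM.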

Compound 3, half-maximal inhibitory concentration: 12000 nM
Beside the measured number, compound 3's estimate is 5.0-fold (0.70 log units) above it; the whole stated range lies above it.
By their numbers in this assay, from the lowest: compounds 3 and 2 (each within the scatter of the next); then compound 1.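

In this assay, the step to a single aromatic ring on this oxygen does not cost activity: a 3.2-fold lower number from compound 1 to compound 3 (0.51 log units; beyond the scatter). Among the compounds shown here, the earlier pair both carried two aromatic rings, so this is the first sign that 4-phenylphenyl can be cut back to 7 heavy atoms here. Nothing at hand accounts for the lower number.

Loss of the second ring and gain of the fluorine came together, so their separate contributions remain open. Plain phenyl, or a chlorine or methoxy group in place of the fluorine, would bear on this.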